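The source may hold more compounds than are shown below. What is called first, only, known or untested is meant among the compounds shown, and "the series" means these compounds.

Measured so far:
compound 1, `CC1N=C(S)N(Nc2cccc(Cl)c2)C1C`: 259000 nM in a functional assay on MT4 cells (Homo sapiens) for cytotoxicity; a lower number here means that less compound is tolerated, a higher number that more compound is tolerated
compound 2, `Cc1cccc(NN2C(S)=NC(C)C2C)c1`: 360000 nM

Going by the values given here, compound 1 holds the lower of the two numbers, but its only neighbour is compound 2, and the step of a 1.4-fold higher number from compound 1 to compound 2 (0.14 log units; within the scatter), a methyl in place of chloro on an aromatic carbon, is within the scatter. Compound 3, `CC1N=C(S)N(Nc2cccc(Cl)c2)C1C(=O)O`, changes a different part of the shared core: carboxy in place of methyl on a saturated ring carbon. Among the compounds with values here, no measured step touches this saturated ring carbon, so the one step known offers no direct guide. The number for compound 3 is therefore expected to stay close to that of compound 1, a step of a 1.2-fold higher number from compound 1 to compound 3 (0.06 log units; within the scatter) that is not expected to exceed the scatter. The estimate for compound 3 in this assay is 300000 nM, with a range from 120000 nM to 800000 nM.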

Compound 3, half-maximal cytotoxic concentration: 266000 nM
For compound 3 the middle estimate is 1.1-fold (0.05 log units) above the measured one, and the stated range covers the measured number.
By their numbers in this assay, from the lowest: compounds 1, 3 and 2 (each within the scatter of the next).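

In this assay, going by these compounds alone, the first step at this saturated ring carbon, carboxy in place of methyl, gives a 1.0-fold higher number from compound 1 to compound 3 (0.01 log units; within the scatter) and so does not separate the two compounds. The larger group, with its added hydrogen-bond donor and acceptor, therefore produces no step beyond the scatter in this single comparison. Nothing available explains this result. Going by these compounds, whether an amine or a longer chain on this carbon would behave the same way stays open. So does whether the same change on the ring atom that bears a methyl group would give a step beyond the scatter.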